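This account rests on a few compounds, and the source may have more. Where it says the series, first, only, none or still open, it means among the compounds named here.

Values in a functional assay, read by spectrophotometry, tested at 100 uM (on this read-out higher numbers stand for weaker inhibition and lower numbers for stronger inhibition), so far:

Compound 1 `O=C(/C=C/c1ccccc1)c1cccc(NC(=O)c2cc(-c3ccncc3)n[nH]2)c1` gives 71500 nM
Compound 2 `O=C(/C=C/c1ccc(Cl)cc1)c1cccc(NC(=O)c2cc(-c3ccncc3)n[nH]2)c1` gives 78900 nM
Compound 3 `CN(C)c1ccc(/C=C/C(=O)c2cccc(NC(=O)c3cc(-c4ccncc4)n[nH]3)c2)cc1` gives 60900 nM

Compound 3 sits level with the other two, and the steps that reach it are a 1.2-fold lower number from compound 1 to compound 3 (0.07 log units; within the scatter) and a 1.3-fold lower number from compound 2 to compound 3 (0.11 log units; within the scatter). Compound 4 `O=C(/C=C/c1ccc([N+](=O)[O-])cc1)c1cccc(NC(=O)c2cc(-c3ccncc3)n[nH]2)c1` has not yet been measured. The change that leads to it is nitro in place of dimethylamino on an aromatic carbon, which in words is nitro in place of dimethylamino on an aromatic carbon, para to a large group.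

All three measured steps were made at this same place, so they are the ones that bear on the change. Besides the two above, the third is a 1.1-fold higher number from compound 1 to compound 2 (0.04 log units; within the scatter). Hydrogen, chloro and dimethylamino have thus been exchanged there without any step leaving the scatter, and none of the three compounds goes against this. Among the measured compounds shown here, no nitro compound has been measured, so the new group itself remains untested, and a larger move cannot be ruled out. For the measured compounds named here, the size of the earlier steps gives no ground for expecting a real shift in either direction.

The expected step is a 1.2-fold higher number from compound 3 to compound 4 (0.07 log units; within the scatter), which would be no change beyond the scatter. Compound 4 is estimated at 72000 nM, with an expected range from 45000 nM to 110000 nM.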

Compound 4, half-maximal inhibitory concentration: 64600 nM
Estimate against measurement, compound 4: 1.1-fold (0.05 log units) above; the range from low to high includes it.
By their numbers in this assay, from the lowest: compounds 3, 4, 1 and 2 (each within the scatter of the next).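

In this assay the exchange of dimethylamino for nitro at this place on the aromatic ring gives a 1.1-fold higher number from compound 3 to compound 4 (0.03 log units; within the scatter) and so adds a fourth group that produces no change beyond the scatter. The same reading holds for the exchange of chloro for nitro, with a 1.2-fold lower number from compound 2 to compound 4 (0.09 log units; within the scatter), and for the exchange of hydrogen for nitro, with a 1.1-fold lower number from compound 1 to compound 4 (0.04 log units; within the scatter). The earlier compounds shown here had left the nitro group untested and a larger move possible, but hydrogen, chloro, dimethylamino and nitro now stand level, and none of the four compounds goes against this.

The compounds shown leave open whether a carboxylic acid or a primary amine at this place, a longer chain there, or a change elsewhere on the shared core would move the number beyond the scatter in this assay. Nothing available here speaks to why these four groups give values so close together.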